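The source may hold more compounds than are shown below. What is called first, only, known or untested is meant among the compounds shown, and "the series" means these compounds.

Going by the values given here, in a functional assay on KB-VIN10 cells (Homo sapiens) for inhibition, with a stated time of 72 h (a higher number here means a weaker inhibitor, a lower number a stronger inhibitor), compound 3 (`COc1ccc(S(=O)(=O)N2CCc3cccc(-c4ccc(F)cc4)c32)cc1`) gives 94.6 nM and stands in the middle of the three numbers so far. Compound 1 (`COc1ccc(S(=O)(=O)N2CCc3cccc(-c4ccc(F)c(F)c4)c32)cc1`) gives the lowest value at 46 nM and compound 2 (`COc1ccc(S(=O)(=O)N2CCc3cccc(-c4ccc(N(C)C)cc4)c32)cc1`) the highest at 553 nM in this set.

The next compound is compound 4 (`COc1ccc(S(=O)(=O)N2CCc3cccc(-c4cccc(F)c4)c32)cc1`). The change is 3-fluorophenyl in place of 4-fluorophenyl on an aromatic carbon and amounts to 3-fluorophenyl in place of 4-fluorophenyl on an aromatic carbon.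

The nearest measured step is a 2.1-fold higher number from compound 1 to compound 3 (0.31 log units; beyond the scatter) and it is modest. Compound 1 carries 3,4-difluorophenyl, so 3-fluorophenyl and 4-fluorophenyl are each one fluoro short of it. The steps of a 5.8-fold lower number from compound 2 to compound 3 (0.77 log units; beyond the scatter) and a 12-fold higher number from compound 1 to compound 2 (1.08 log units; beyond the scatter) exchange dimethylamino for fluoro or difluoro substitution and bear on this change only weakly. Among the compounds with values here, no measured pair moves a fluoro around the ring, so there is no direct precedent.

A step within the scatter is therefore expected, with no firm direction. The expected step is a 1.1-fold lower number from compound 3 to compound 4 (0.05 log units; within the scatter) in this assay on this reasoning. For compound 4 the estimate is 85 nM with 35 nM to 210 nM as the expected range.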

Compound 4, half-maximal inhibitory concentration: 92.4 nM
Estimate against measurement, compound 4: 1.1-fold (0.04 log units) below; the measured number falls inside the stated range.
By their numbers in this assay, from the lowest: compounds 1, 4 and 3 (each within the scatter of the next, the first and the last beyond it); then compound 2.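

In this assay, moving the fluoro from 4-fluorophenyl to 3-fluorophenyl leaves the number effectively unchanged, with a 1.0-fold lower number from compound 3 to compound 4 (0.01 log units; within the scatter), so these two placements of a single fluoro cannot be told apart. The exchange of 4-(dimethylamino)phenyl for a fluorophenyl stays beyond the scatter with the new isomer, at a 6.0-fold lower number from compound 2 to compound 4 (0.78 log units; beyond the scatter), whereas a 2.0-fold higher number from compound 1 to compound 4 (0.30 log units; within the scatter) lies within it, so compound 4 cannot be separated from compound 1 or compound 3. No available measurement accounts for any of these steps.

Still open, on these data alone, is whether any fluoro is needed, a question that unsubstituted phenyl would address. It is also unclear whether the tolerance seen here extends to other groups in place of the fluoro, such as chloro, methoxy or a carboxylic acid.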